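The compounds below may be only part of what the source reports. "The series", "measured", "known", "first", "only" and "open" are said of these compounds alone.

Compound 1 `CN(C(=O)NC(=O)c1ccc(F)c(F)c1)c1nc(C(F)(F)F)c(C(=O)N/N=C/c2ccc(C(F)(F)F)cc2)s1` gives 6.26 ug/mL in a functional assay on HepG2 cells (Homo sapiens) for inhibition, read by MTT assay, with a stated time of 72 h (on this read-out lower numbers stand for stronger inhibition and higher numbers for weaker inhibition), and stands at one end of the two numbers shown, which differ by no more than the scatter. In this assay compound 2 `CN(C(=O)NC(=O)c1ccc(F)c(F)c1)c1nc(C(F)(F)F)c(C(=O)N/N=C/c2ccc([N+](=O)[O-])cc2)s1` gives 6.23 ug/mL; the step of a 1.0-fold lower number from compound 1 to compound 2 (0.00 log units; within the scatter) is within the scatter. Compound 3 `CN(C(=O)NC(=O)c1ccccc1F)c1nc(C(F)(F)F)c(C(=O)N/N=C/c2ccc(C(F)(F)F)cc2)s1` differs from compound 1 by 2-fluorophenyl in place of 3,4-difluorophenyl on a carbonyl carbon. For the measured compounds named here, no measured step touches that end of the molecule, and the single step measured elsewhere was flat, so no shift beyond the scatter is expected. Compound 3 is therefore estimated to show a 1.0-fold higher number from compound 1 to compound 3 (0.02 log units; within the scatter), with a value of 6.5 ug/mL, between 3 ug/mL and 14 ug/mL.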

Compound 3, half-maximal inhibitory concentration: 4.56 ug/mL
Compound 3: the middle estimate sits 1.4-fold (0.15 log units) above what was measured, within the range that was stated.
By their numbers in this assay, from the lowest: compounds 3, 2 and 1 (each within the scatter of the next).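

In this assay, 2-fluorophenyl in place of 3,4-difluorophenyl on a carbonyl carbon gives a 1.4-fold lower number from compound 1 to compound 3 (0.14 log units; within the scatter). For the compounds shown here, this is the first step at this end of the molecule, and it shows that this end tolerates this change without a shift beyond the scatter, as the earlier step elsewhere did. Nothing at hand gives a reason for this result. Only this one change at this place is shown, so the separate roles of the fluorines stay open. On these data alone, whether an amine or a carboxylic acid on the phenyl would move the number beyond the scatter also stays open.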